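Moving the chlorine on the anilino ring of a quinazoline-like series

This account rests on a few compounds, and the source may have more. Where it says the series, first, only, none or still open, it means among the compounds named here.

Of the compounds shown here, two have been measured in a functional assay on NCI-H1975 cells (Homo sapiens) for inhibition, read by MTT assay, with a stated time of 72 h; on this read-out lower numbers stand for stronger inhibition and higher numbers for weaker inhibition. Compound 1 `O=C(CSc1nc(Nc2ccccc2)c2ccccc2n1)Nc1cccc(Cl)c1` gives 8460 nM in this assay. Compound 2 `C=CC(=O)Nc1cccc(NC(=O)CSc2nc(Nc3ccccc3Cl)c3ccccc3n2)c1` gives 10000 nM in this assay, the highest of the two numbers, though its gap to compound 1 is within the scatter, so the two compounds cannot be ranked against each other on these data. Compound 3 `C=CC(=O)Nc1cccc(NC(=O)CSc2nc(Nc3ccc(Cl)cc3)c3ccccc3n2)c1` has not yet been measured. It differs from compound 2 only in one place: 4-chlorophenyl in place of 2-chlorophenyl on a nitrogen on an aromatic ring. Going by the values given here, no step between measured compounds that differ in a single place is available here, so nothing in the measured pairs says how such a change plays out in this assay. The step from compound 2 to compound 3 is therefore expected to stay within the scatter, with no clear direction, and the estimated step is a 1.2-fold lower number from compound 2 to compound 3 (0.07 log units; within the scatter). For compound 3 the estimate is 8500 nM, with a range from 3000 nM to 20000 nM.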

Compound 3, half-maximal inhibitory concentration: 7580 nM
The estimate for compound 3 lay 1.1-fold (0.05 log units) above the measured number; measured number inside the range.
By their numbers in this assay, from the lowest: compounds 3, 1 and 2 (each within the scatter of the next).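

In this assay, going by these compounds alone, the change from 2-chlorophenyl to 4-chlorophenyl on a nitrogen on an aromatic ring gives a 1.3-fold lower number from compound 2 to compound 3 (0.12 log units; within the scatter), the first step in this set that changes only one place. Moving the chlorine around this ring therefore does not separate compound 2 and compound 3 on this read-out, and the two cannot be ranked. Nothing available explains this result or bears on it.

On these data alone, whether a different group on that ring, such as a methoxy group, a trifluoromethyl group or a dimethylamino group, would give a step beyond the scatter remains open. As far as these compounds go, compound 1 differs from compound 2 in more than one place, so what the acrylamide contributes on its own also remains open.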